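A few compounds are considered here, and "the series" means these few. Any claim that something is new, unique, unknown or untested is made for them only; others in the source may bear on it.

Measured compounds:
compound 2 `NS(=O)(=O)c1ccc(Nc2nc3nc(=S)[nH]c(-c4ccccc4)c3s2)cc1`: 333 nM
compound 1 `COc1ccc(-c2[nH]c(=O)nc3nc(Nc4ccc(S(N)(=O)=O)cc4)sc23)cc1`: 667 nM

In a functional assay on Caco-2 cells (Homo sapiens) for cytotoxicity, read by MTT assay, with a stated time of 24 h (on this read-out lower numbers stand for stronger inhibition and higher numbers for weaker inhibition), compound 2 gives 333 nM, the lower of the two numbers, though compound 1 with 667 nM sits within the scatter of it, so no order can be read between them. For the measured compounds named here, compound 1 and compound 2 differ in more than one place, so that pair gives no single step.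

Compound 3 `COc1ccc(-c2[nH]c(=S)nc3nc(Nc4ccc(S(N)(=O)=O)cc4)sc23)cc1` differs from compound 2 by methoxy in place of hydrogen on an aromatic carbon. Going by the values given here, no measured pair shows this change alone. The value for compound 3 is expected at 400 nM, with a range from 150 nM to 1100 nM. The expected step of a 1.2-fold higher number from compound 2 to compound 3 (0.08 log units; within the scatter) is small and lies within the scatter, in no clear direction.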

Compound 3, half-maximal inhibitory concentration: 667 nM
Compound 3: the middle estimate sits 1.7-fold (0.22 log units) below what was measured; measured number inside the range.
By their numbers in this assay, from the lowest: compounds 2, 1 and 3 (each within the scatter of the next).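

In this assay, for the compounds shown here, the change from phenyl to 4-methoxyphenyl provides the first comparison that differs in one place, with a 2.0-fold higher number from compound 2 to compound 3 (0.30 log units; within the scatter) as its step. Methoxy on this aromatic carbon therefore leaves the read-out within the scatter, and this single pair gives no direction for the change. The compounds shown leave open whether an amine, a carboxylic acid or a longer alkoxy chain at this position would carry the number beyond the scatter. No supporting measurement is available to explain the step.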